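Benzyl to 4-methylbenzyl: working notes on compound 4

The compounds below may be only part of what the source reports. "The series", "measured", "known", "first", "only" and "open" are said of these compounds alone.

In a functional assay on HL-60 cells (Homo sapiens) for inhibition, read by CCK-8 assay, with a stated time of 48 h (on this read-out higher numbers stand for weaker inhibition and lower numbers for stronger inhibition), compound 3 (`COc1ccc(S(=O)(=O)Oc2ccccc2/C=C(\C#N)C(=O)Nc2nnc(Cc3ccccc3)s2)cc1`) gives 3170 nM and sits at the low end of the three numbers, level within the scatter with compound 2 (`COc1ccc(S(=O)(=O)Oc2ccccc2/C=C(\C#N)C(=O)Nc2nnc(Cc3cccc4ccccc34)s2)cc1`) at 4700 nM on the same read-out. Compound 1 (`COc1ccc(Cc2nnc(NC(=O)/C(C#N)=C/c3ccccc3OS(=O)(=O)c3ccc([N+](=O)[O-])cc3)s2)cc1`) gives 10900 nM as a higher number than compound 3, a gap beyond the scatter. Among the measured compounds shown here, compound 1 differs from compound 3 in more than one place and offers no single step.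

Compound 4 (`COc1ccc(S(=O)(=O)Oc2ccccc2/C=C(\C#N)C(=O)Nc2nnc(Cc3ccc(C)cc3)s2)cc1`) turns benzyl into 4-methylbenzyl, with methyl in place of hydrogen on an aromatic carbon. For the measured compounds named here, the one measured step on this aromatic group is a 1.5-fold lower number from compound 2 to compound 3 (0.17 log units; within the scatter) with phenyl in place of naphthalen-1-yl, and it stays within the scatter. The methyl change is smaller, so no step beyond the scatter is expected in this assay here. The estimated step is a 1.1-fold lower number from compound 3 to compound 4 (0.02 log units; within the scatter) and stays within the scatter. For compound 4 the expected value is 3000 nM with an estimated range from 1300 nM to 7000 nM on this read-out.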

Compound 4, half-maximal inhibitory concentration: 4080 nM
For compound 4 the middle estimate is 1.4-fold (0.13 log units) below the measured one, and the stated range covers the measured number.
By their numbers in this assay, from the lowest: compounds 3, 4 and 2 (each within the scatter of the next); then compound 1.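

In this assay, among the compounds shown here, the first change on the aromatic ring itself, methyl in place of hydrogen para to a large group, gives a 1.3-fold higher number from compound 3 to compound 4 (0.11 log units; within the scatter) and so shifts the number by no more than repeat measurements would. Against the larger aryl group the result is the same, with a 1.2-fold lower number from compound 2 to compound 4 (0.06 log units; within the scatter) for 4-methylphenyl in place of naphthalen-1-yl, so phenyl, 4-methylphenyl and naphthalen-1-yl on the saturated chain carbon all stand level within the scatter. No supporting measurement is available to explain this flat result.

Going by these compounds, whether any group at this position can move the number beyond the scatter stays open, for instance an amine or a carboxylic acid in place of the methyl. The compounds shown also leave open whether a longer chain there would behave as methyl does.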